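Swapping a Succinamic Acid Chain for Fluorine

The source may hold more compounds than are shown below. What is called first, only, known or untested is meant among the compounds shown, and "the series" means these compounds.

Compound 1, `O=C(O)CCC(=O)Nc1ccc(-c2nc3cc(C(F)(F)F)ccc3[nH]2)cc1`, in an ADME assay on BHK cells (Mesocricetus auratus) for cytotoxicity, read by MTT assay, with a stated time of 96 h (on this read-out lower numbers stand for higher toxicity in this test and higher numbers for lower toxicity in this test), gives > 100000 nM.
Compound 2, `O=C(CN1CCCCC1)Nc1ccc(-c2nc3cc(Cl)c(Cl)cc3[nH]2)cc1`, in this assay gives 39000 nM.
Compound 3, `Cn1c(-c2ccc(NC(=O)CN3CCN(c4ccccc4)CC3)cc2)nc2cc(C(F)(F)F)ccc21`, in this assay gives 100000 nM.

The value of compound 1 is a limit of the assay, not a measured number, as the line the limit of > 100000 nM in this assay, at which 1 of the 3 values shown sits, records. Among the three measured compounds only compound 2 has a numerical value, and compound 3 sits at the upper end of the measured range, so compound 1 can only be placed at or beyond the least toxic end of what was seen.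

Compound 4, `Fc1ccc(-c2nc3cc(C(F)(F)F)ccc3[nH]2)cc1`, differs from compound 1 in one place: fluoro in place of ((2-carboxyethyl)carbonyl)amino on an aromatic carbon. Going by the values given here, no pair of measured compounds differs in a single place, so no measured step can be used as a guide.

Given that compound 1 sits at a limit, the step from compound 1 to compound 4 is expected to be toward higher toxicity, that is a lower number, of a size that may or may not exceed the scatter, so that an at least 2.5-fold lower number from compound 1 to compound 4 (0.39 log units; beyond the scatter) is an estimate rather than a firm step. Compound 4 is expected to give 40000 nM in this assay, with a likely range from 10000 nM to 150000 nM.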

Compound 4, half-maximal cytotoxic concentration: 25000 nM
Compound 4: the middle estimate sits 1.6-fold (0.20 log units) above what was measured; low and high end bracket the measured number.
By their numbers in this assay, from the lowest: compounds 4 and 2 (each within the scatter of the next); then compound 3.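

In this assay, putting fluoro in place of the ((2-carboxyethyl)carbonyl)amino group on the aromatic carbon gives an at least 4.0-fold lower number from compound 1 to compound 4 (0.60 log units; beyond the scatter), the first single-change comparison available in this set. The earlier compounds shown here differ from one another in several places at once, so only now can a change in toxicity in this test be tied to this one position, para to a large group, with the rest of the core of compound 1 kept. The value of compound 1 is a limit, so the step has a lower bound and no exact size: the limit of > 100000 nM in this assay, at which 1 of the 4 values shown sits.

The compounds shown leave open which feature of the departing chain matters, whether its end carboxylic acid, its amide, or simply its length, and whether fluoro itself plays any part or the result reflects only the loss of the chain. A plain amine, a carboxylic acid set directly on the ring, a longer chain ending in an ester, or hydrogen at this same position could each separate these possibilities, and any of them would also show how far this single step can be generalized.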